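From 3-Bromophenyl to 4-Methylphenyl: Little Change Expected

The source may report more compounds than this note shows. Statements on the series, on what has been measured and on what is new or still open speak of the compounds shown alone.

Of the compounds shown here, two have numbers so far, compound 1 (`NC(=O)c1ccc(Nc2nccc(Nc3ccc4cn[nH]c4c3)n2)cc1`) and compound 2 (`Brc1cccc(Nc2nccc(Nc3ccc4cn[nH]c4c3)n2)c1`). In an ADME assay on HepG2 cells (Homo sapiens) for inhibition, read by fluorescence and resazurin assay, with a stated time of 72 h (on this read-out lower numbers stand for stronger inhibition and higher numbers for weaker inhibition), compound 1 gives 16000 nM as its half-maximal inhibitory concentration, and compound 2 gives 17000 nM on the same read-out. These two numbers lie within the usual scatter of repeated measurements, so compound 2 stands level with compound 1 and neither can be told apart from the other.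

Compound 3 (`Cc1ccc(Nc2nccc(Nc3ccc4cn[nH]c4c3)n2)cc1`) has not yet been measured. Compared with compound 2, it carries 4-methylphenyl in place of 3-bromophenyl on a nitrogen on an aromatic ring. Among the measured compounds shown here, no measured pair shows directly what this swap does, so the expectation rests only on the close agreement of compound 1 at 16000 nM and compound 2 at 17000 nM in this range. In this assay the estimated step is a 1.1-fold lower number from compound 2 to compound 3 (0.05 log units; within the scatter) and that is expected to stay within the scatter, with no firm direction. The expected value for compound 3 is 15000 nM with an estimated range from 7000 nM to 30000 nM around it.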

Compound 3, half-maximal inhibitory concentration: 18000 nM
Compound 3: the middle estimate sits 1.2-fold (0.08 log units) below what was measured, within the range that was stated.
By their numbers in this assay, from the lowest: compounds 1, 2 and 3 (each within the scatter of the next).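

In this assay, among the compounds shown here, the first single swaps at this site can now be read: 4-methylphenyl in place of 3-bromophenyl gives a 1.1-fold higher number from compound 2 to compound 3 (0.02 log units; within the scatter) and stays within the scatter, while methyl in place of carbamoyl on an aromatic carbon gives a 1.1-fold higher number from compound 1 to compound 3 (0.05 log units; within the scatter) and also stays within the scatter. Compound 3 therefore cannot be told apart from either neighbour, so neither exchanging 3-bromophenyl for 4-methylphenyl nor replacing carbamoyl with methyl moves the read-out by more than repeat measurements would. No supporting data accompany these numbers that could say why the three compounds sit at one level.

Still open, as far as these compounds go, is whether any group on this phenyl ring can move the number beyond the scatter, for example a carboxylic acid, an amine or a longer chain in place of the methyl of compound 3. Also open, from the compounds shown here alone, is whether 4-bromophenyl or 3-methylphenyl would read the same, which would separate the effect of the group from the effect of where it sits on the ring.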